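Swapping a Cyclopropyl for Benzylamino on a Thiazole Amide

This account rests on a few compounds, and the source may have more. Where it says the series, first, only, none or still open, it means among the compounds named here.

Of the compounds shown here, two sharing a fused bicyclic core have been tested in a functional assay on WI-38 VA13 cells (Homo sapiens) for cytotoxicity; on this read-out lower numbers stand for an effect already at smaller amounts and higher numbers for an effect only at larger amounts of compound. Compound 1 `N#Cc1cccc(C(=O)Nc2ccc3nc(NC(=O)C4CCCCC4)sc3c2)c1` carries a cyclohexyl amide and a nitrile-bearing benzamide; in this assay compound 1 gives 0.52 ug/mL. Compound 2 `O=C(Nc1ccc2nc(NC(=O)C3CC3)sc2c1)c1c(Cl)cccc1Cl` instead carries a cyclopropyl amide and a dichlorinated benzamide, and in this assay compound 2 gives 0.013 ug/mL, the lower of the two numbers, with compound 1 sitting far higher, well beyond the usual scatter.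

Compound 3 `O=C(NCc1ccccc1)Nc1nc2ccc(NC(=O)c3c(Cl)cccc3Cl)cc2s1` is the next step from compound 2. The change is benzylamino in place of cyclopropyl on a carbonyl carbon: the cyclopropyl leaves and benzylamino enters on the carbonyl carbon whose other neighbour is an amide-type nitrogen, so the cyclopropylcarbonyl becomes a benzylcarbamoyl.

Within the data shown here, no pair of measured compounds shows this change, so there is no measured step to lean on. In this assay the expected step from compound 2 to compound 3 is a 3.8-fold higher number from compound 2 to compound 3 (0.59 log units; beyond the scatter), a moderate move toward a higher number, though a result within the scatter would not surprise. Compound 3 is therefore estimated at 0.05 ug/mL, within a range from 0.01 ug/mL to 0.3 ug/mL.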

Compound 3, half-maximal effective concentration: 0.15 ug/mL
Estimate against measurement, compound 3: 3.0-fold (0.48 log units) below, and the stated range covers the measured number.
By their numbers in this assay, from the lowest: compound 2; then compound 3; then compound 1.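

Among these compounds, this is the first direct reading of what the group on this carbonyl carbon does, since only this one place changes while the dichlorinated benzamide and the shared core stay the same. In this assay, putting benzylamino in place of cyclopropyl gives a 12-fold higher number from compound 2 to compound 3 (1.06 log units; beyond the scatter), a large step. The read-out is therefore clearly sensitive to the group at this place, at least for this one swap, in which 3 heavy atoms of cyclopropyl give way to 8 heavy atoms of benzylamino, bringing an aromatic ring and a hydrogen-bond donor.

Nothing available explains the step, and this single pair cannot separate the contributions of the ring, the added nitrogen and the larger group.

The compounds shown leave open whether a plain amino group or a methylamino group on this carbonyl carbon would stay nearer to cyclopropyl or nearer to benzylamino, and whether phenylamino, with its ring one carbon closer, would behave like benzylamino. From the compounds shown here alone, it is also open whether the same swap would produce a step of similar size alongside the nitrile-bearing benzamide of compound 1.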